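The compounds below may be only part of what the source reports. "The series", "measured", "known", "first", "only" and "open" are said of these compounds alone.

Measured so far:
Compound 1 `Cc1ccccc1-c1nnc(NN)s1` gives > 100 mg/kg in a functional assay on the whole organism with Mus musculus as the target, in the maximal electroshock model, with a stated time of 1 h (on this read-out lower numbers stand for an effect already at smaller amounts and higher numbers for an effect only at larger amounts of compound), which is a limit of the assay rather than a number.
Compound 2 `Cc1ccccc1-c1nnc(NNC(C)C)s1` gives 83 mg/kg in this assay.
Compound 3 `CC(C)NNc1nnc(-c2ccccc2-c2ccccc2)s1` gives 35 mg/kg in this assay.

Among the two numbers, compound 2 holds the higher one; the single step away from it is a 2.4-fold lower number from compound 2 to compound 3 (0.38 log units; beyond the scatter), which alters the aromatic substituent and so says little about the hydrazine end. Compound 4 `Cc1ccccc1-c1nnc(NN(C)C)s1` differs from compound 2 in one way: dimethylamino in place of isopropylamino on a nitrogen on an aromatic ring. Among the compounds with values here, the only measured step at that nitrogen is an at least 1.2-fold lower number from compound 1 to compound 2 (0.08 log units; that floor lies within the scatter), whose floor does not rise above the scatter. The change to compound 4 is therefore expected to amount to a 1.0-fold lower number from compound 2 to compound 4 (0.02 log units; within the scatter) in this assay, no step beyond the scatter. Compound 4 is expected to give about 80 mg/kg, within 35 mg/kg to 200 mg/kg.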

Compound 4, dose for half-maximal effect: 60 mg/kg
Compound 4: middle estimate off by 1.3-fold (0.12 log units), on the high side; low and high end bracket the measured number.
By their numbers in this assay, from the lowest: compounds 3, 4 and 2 (each within the scatter of the next, the first and the last beyond it). At a limit, above all of these: compound 1.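

Swapping isopropylamino for dimethylamino at this nitrogen takes the group from 1 hydrogen-bond donor to 0 and gives a 1.4-fold lower number from compound 2 to compound 4 (0.14 log units; within the scatter) in this assay, so a number in this range does not depend on that donor. Compared with the plain amino group, the change reads as an at least 1.6-fold lower number from compound 1 to compound 4 (0.22 log units; that floor lies within the scatter). Compound 1 stands at a limit of the assay, so that step is only a floor: the limit of > 100 mg/kg in this assay, at which 1 of the 4 values shown sits.

Still open, as far as these compounds go, is how a longer chain such as butyl, or a cyclohexyl ring, would fare on this nitrogen. Also open, from the compounds shown here alone, is whether dimethylamino would behave the same alongside the phenyl group of compound 3.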